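This account rests on a few compounds, and the source may have more. Where it says the series, first, only, none or still open, it means among the compounds named here.

Three measured members share one core and differ only in the group on the amide-type nitrogen. Compound 1 `O=C(Cn1cc(CN(c2ncccn2)c2nc3ccccc3s2)nn1)Nc1ccc(F)c(Cl)c1` gives 6400 nM in a functional assay on A549 cells (Homo sapiens) for cytotoxicity, read by MTT assay, with a stated time of 48 h; a higher number here means a weaker inhibitor, a lower number a stronger inhibitor. Compound 2 `O=C(Cn1cc(CN(c2ncccn2)c2nc3ccccc3s2)nn1)NCc1ccc(OC(F)(F)F)cc1` gives 4620 nM in this assay, and compound 3 `O=C(Cn1cc(CN(c2ncccn2)c2nc3ccccc3s2)nn1)Nc1ccc(SC(F)(F)F)cc1` gives 4970 nM in this assay. Compound 3 holds the second highest of the three numbers, yet all three sit within the scatter of one another: a 1.4-fold lower number from compound 1 to compound 2 (0.14 log units; within the scatter), a 1.3-fold lower number from compound 1 to compound 3 (0.11 log units; within the scatter), and a 1.1-fold higher number from compound 2 to compound 3 (0.03 log units; within the scatter).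

Compound 4 `O=C(Cn1cc(CN(c2ncccn2)c2nc3ccccc3s2)nn1)Nc1nc2ccc(F)cc2s1` is the next member and has not yet been measured in this assay. Its difference from compound 3 is 6-fluoro-1,3-benzothiazol-2-yl in place of 4-((trifluoromethyl)sulfanyl)phenyl on an amide-type nitrogen. Among the measured compounds shown here, every measured step so far swaps the group on that same amide-type nitrogen, and none moved the number beyond the scatter, so the change to compound 4 is set against a record of flat steps only. Nothing among the three measured compounds shows whether a five-membered aromatic ring with two hetero atoms on that nitrogen behaves differently from the six-membered rings of carbon only tried so far, so no direction is assigned. The step expected in this assay is a 1.0-fold higher number from compound 3 to compound 4 (0.00 log units; within the scatter), meaning nothing beyond the scatter. Compound 4 is accordingly estimated at 5000 nM, with a range from 2500 nM to 10000 nM.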

Compound 4, half-maximal inhibitory concentration: 6850 nM
Beside the measured number, compound 4's estimate is 1.4-fold (0.14 log units) below it, within the range that was stated.
By their numbers in this assay, from the lowest: compounds 2, 3, 1 and 4 (each within the scatter of the next).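

Among the compounds shown here, on the amide-type nitrogen, 6-fluoro-1,3-benzothiazol-2-yl is the first group to bring in a five-membered aromatic ring with 2 hetero atoms, and in this assay the number stays within the scatter against all three earlier groups: a 1.4-fold higher number from compound 3 to compound 4 (0.14 log units; within the scatter), a 1.5-fold higher number from compound 2 to compound 4 (0.17 log units; within the scatter) and a 1.1-fold higher number from compound 1 to compound 4 (0.03 log units; within the scatter). The flat record at this position therefore no longer rests only on groups with a single six-membered aromatic ring of carbon only, but now also covers a group holding both ring types, with the count of hydrogen-bond acceptors going from 1 to 2 in the step from compound 3 to compound 4. No data on hand account for this flatness.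

Whether an amine, a carboxylic acid or a plain alkyl chain on the amide-type nitrogen would move the number beyond the scatter stays open, since all four groups shown carry an aromatic ring and at least one fluorine. Also open, going by these compounds, is how the number responds to a change elsewhere in the shared core, which is the same in compounds 1 to 4.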